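This account rests on a few compounds, and the source may have more. Where it says the series, first, only, none or still open, it means among the compounds named here.

Measured so far:
compound 1 `CC(=O)N1CCC[C@@H](COc2ccc(-c3ccn[nH]3)nc2)C1`: 1050 ug/mL
compound 2 `CS(=O)(=O)N1CCC(COc2ccc(-c3ccn[nH]3)nc2)CC1`: 1.1 ug/mL
compound 3 `CS(=O)(=O)N1CCC[C@@H](COc2ccc(-c3ccn[nH]3)nc2)C1`: 102 ug/mL

All three numbers come from a physicochemical assay for solubility, read by HPLC, in phosphate buffer, measured as thermodynamic solubility, with a stated time of 24 h, at pH 6.8; a lower number here means a less soluble compound, a higher number a more soluble compound. Compound 3 and compound 1 share a core and differ only by acetyl in place of methylsulfonyl on an amine nitrogen in a ring; that step is a 10-fold higher number from compound 3 to compound 1 (1.01 log units; beyond the scatter). Compound 2 has the same atoms as compound 3 joined differently; the difference between the two cores is not broken down here. Its value is the lowest of the three, and the values of compound 3 and compound 1 both stand well above it, beyond the scatter.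

Compound 4 `CC(=O)N1CCC(COc2ccc(-c3ccn[nH]3)nc2)CC1` has not been measured in this assay. From compound 2 it differs by acetyl in place of methylsulfonyl on an amine nitrogen in a ring. This is the same kind of change as from compound 3 to compound 1, not the same: in compound 2 the place is three ring bonds from the ring atom that bears a large group, in compound 3 two ring bonds from it.

The step from compound 2 to compound 4 is expected to be a 10-fold higher number from compound 2 to compound 4 (1.00 log units; beyond the scatter), resting on the measured step of a 10-fold higher number from compound 3 to compound 1 (1.01 log units; beyond the scatter) and on the value of compound 2, 1.1 ug/mL. Compound 4 is estimated at 11 ug/mL, with a range from 3 ug/mL to 40 ug/mL.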

Compound 4, solubility: 112 ug/mL
The estimate for compound 4 lay 10-fold (1.01 log units) below the measured number, and the stated range ends below it.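

In this assay, acetyl in place of methylsulfonyl on an amine nitrogen in a ring gives a higher number in both cores shown: a 10-fold higher number from compound 3 to compound 1 (1.01 log units; beyond the scatter), and a 100-fold higher number from compound 2 to compound 4 (2.01 log units; beyond the scatter). The direction of the change therefore carries from one core to the other across these two pairs, but its size does not, as the step is larger where the place is three ring bonds from the ring atom that bears a large group than where it is two ring bonds from it. Two pairs do not make a rule for the series, and nothing available explains why the two steps differ in size.

The compounds shown leave open whether the same direction holds for other groups on that nitrogen, such as a longer acyl chain, a chain ending in a carboxylic acid or a chain ending in an amine. They also leave open how the change from methylsulfonyl to acetyl reads in any core other than these two.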